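The compounds below may be only part of what the source reports. "The series", "measured", "known", "first", "only" and "open" are said of these compounds alone.

Measured so far:
compound 1, `COc1ccc2c(c1)C(=O)C(=O)N2CCCCn1cc(COc2cc(=O)oc3ccccc23)nn1`, 41%
compound 2, `O=C1C(=O)N(CCCCn2cc(COc3cc(=O)oc4ccccc34)nn2)c2ccccc21`, 68%
compound 3, `O=C1C(=O)N(CCCCCn2cc(COc3cc(=O)oc4ccccc34)nn2)c2ccccc21`, 62%

All three were tested in a functional assay on COLO 205 cells (Homo sapiens) for inhibition, read by sulforhodamine B assay, with a stated time of 48 h, tested at 50 uM; a lower number here means less inhibition of growth, a higher number more inhibition of growth at the concentration tested. Compound 2 and compound 1 differ in one place only: methoxy in place of hydrogen on an aromatic carbon. That change gave a number 27 percentage points lower from compound 2 to compound 1 (beyond the scatter). Compound 3 differs from compound 2 in more than one place; the difference between the two cores is not broken down here. In this assay compound 3 gives 62% and compound 2 gives 68%, a gap within the usual scatter, so these two cannot be ranked against each other. Compound 4, `COc1ccc2c(c1)C(=O)C(=O)N2CCCCCn1cc(COc2cc(=O)oc3ccccc23)nn1`, has not yet been measured. Among the measured compounds shown here, it differs from compound 3 by methoxy in place of hydrogen on an aromatic carbon, the same change at the same place as the one seen between compound 2 and compound 1. For the measured compounds named here, for compound 4 a downward step of similar size is expected, namely a number 25 percentage points lower from compound 3 to compound 4 (beyond the scatter), because the single earlier example of this change produced a number 27 percentage points lower from compound 2 to compound 1 (beyond the scatter). Resting on only one precedent, the expectation is held loosely. In this assay compound 4 is therefore estimated at 37%, with a plausible range from 22% to 52%.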

Compound 4, percent growth inhibition at one concentration: 19%
Compound 4: the middle estimate sits 18 percentage points above what was measured; measured number outside the range, below it.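

In this assay, methoxy in place of hydrogen on an aromatic carbon lowers the number on the second core as well, giving a number 43 percentage points lower from compound 3 to compound 4 (beyond the scatter). The direction of the change carried over from one core to the other, but its size did not, so a step measured on one core is a poor guide to the exact size of the step on the other: the same change on two cores in this assay, a number 27 percentage points lower (beyond the scatter) from compound 2 to compound 1 and a number 43 percentage points lower (beyond the scatter) from compound 3 to compound 4, 16 percentage points apart, beyond the scatter of two such steps. These two pairs do not show what in the cores sets the two steps apart, and they give no rule for any other core, since they rest on a single cell line at a single tested concentration.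

The compounds shown leave open whether a fluorine or a hydroxyl on the same aromatic carbon would also lower the number, or whether this is particular to methoxy. Among the compounds shown here, they also leave open what size the methoxy step would take on a core with a longer chain than the one in compound 4.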